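A few compounds are considered here, and "the series" means these few. Any claim that something is new, unique, unknown or untested is made for them only; others in the source may bear on it.

In an ADME assay on HCT-116 cells (Homo sapiens) for cytotoxicity, read by CellTiter-Glo, with a stated time of 72 h (a lower number here means a stronger inhibitor, a higher number a weaker inhibitor), three compounds that share a core have been tested, and none has yet given an exact number. Compound 1 `CC1CCN(C2CCN(S(=O)(=O)c3cccc(C(F)(F)F)c3)CC2)CC1` gives > 5000 nM, which is a limit of the assay. Compound 3 `COc1ccccc1-c1ccc(S(=O)(=O)N2CCC(N3CCC(C)CC3)CC2)cc1` gives > 5000 nM, also a limit. Compound 2 `CC1CCN(C2CCN(S(=O)(=O)c3cccnc3)CC2)CC1`, the starting point here, gives > 10000 nM, again a limit. Compound 4 `CC1CCN(C2CCN(S(=O)(=O)c3nccn3C)CC2)CC1` carries 1-methyl-1H-imidazol-2-yl in place of pyridin-3-yl on a sulfonyl sulfur. For the measured compounds named here, no measured pair shows what such a swap does in this assay, so no change beyond the usual scatter is expected, in either direction. The expected step is a number no higher from compound 2 to compound 4 (the limit leaves the size open). The estimate for compound 4 is 10000 nM, with an expected range of 5000 nM to 20000 nM.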

Compound 4, half-maximal inhibitory concentration: > 10000 nM
Compound 4 ended at the assay's limit (the forecaster's own chance of this, stated with the estimate: 85%); the middle value lies on the limit itself.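

No step can be read between compound 2 and compound 4, since both sit at one limit of the assay: the limit of > 10000 nM in this assay, at which 2 of the 4 values shown sit.

What changing the group on the sulfonyl sulfur does to the value stays open: none of the four compounds shown gives an exact number.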